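The source may hold more compounds than are shown below. What is called first, only, known or untested is meant among the compounds shown, and "the series" means these compounds.

Measured in an ADME assay for permeability, using PAMPA, with a stated time of 4 h; on this read-out lower numbers stand for lower permeability and higher numbers for higher permeability:
- Compound 1 `Cn1c(COc2cccc(C(=O)O)c2)nc2ccc(Oc3ccc(Cl)c(F)c3)nc21`: 25.6 10^-6 cm/s
- Compound 2 `Cn1c(COc2cccc(C(=O)O)c2)nc2ccc(Oc3ccc(F)cc3)nc21`: 8.6 10^-6 cm/s
- Compound 3 `Cc1cc(C)cc(Oc2ccc3nc(COc4cccc(C(=O)O)c4)n(C)c3n2)c1`: 17.4 10^-6 cm/s

Compound 2 has the lowest number of the three, and its steps to both others lie beyond the scatter. Compound 4 `Cn1c(COc2cccc(C(=O)O)c2)nc2ccc(Oc3ccc4c(c3)OCC4)nc21`, not yet measured, keeps the core of compound 2 and changes only the group on an oxygen on an aromatic ring: a group of 9 heavy atoms (8 carbon, 1 oxygen; one five-membered non-aromatic ring with 1 hetero atom, one six-membered aromatic ring of carbon only) in place of a group of 7 heavy atoms (6 carbon, 1 fluorine; one six-membered aromatic ring of carbon only), on an oxygen on an aromatic ring.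

Three measured steps change that same place. The first is a 3.0-fold lower number from compound 1 to compound 2 (0.47 log units; beyond the scatter). The second is a 2.0-fold higher number from compound 2 to compound 3 (0.31 log units; beyond the scatter). The third, a 1.5-fold lower number from compound 1 to compound 3 (0.17 log units; within the scatter), does not involve the 4-fluorophenyl group. So both measured replacements for 4-fluorophenyl give higher numbers, but neither contains a five-membered non-aromatic ring, and these steps guide the estimate only loosely.

A modest rise in this assay is therefore expected. The expected change is a 1.5-fold higher number from compound 2 to compound 4 (0.18 log units; within the scatter). For compound 4 the estimated value is 13 10^-6 cm/s, with an expected range from 6 10^-6 cm/s to 28 10^-6 cm/s.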

Compound 4, apparent permeability: 9.1 10^-6 cm/s
Estimate against measurement, compound 4: 1.4-fold (0.15 log units) above; the measured number falls inside the stated range.
By their numbers in this assay, from the lowest: compounds 2, 4, 3 and 1 (each within the scatter of the next, the first and the last beyond it).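

In this assay, the group with the five-membered non-aromatic ring gives a 1.1-fold higher number from compound 2 to compound 4 (0.02 log units; within the scatter), so at this place on the oxygen it cannot be told apart from 4-fluorophenyl, even though it adds a ring and a hydrogen-bond acceptor. Against the 3,5-dimethylphenyl group the result is a 1.9-fold lower number from compound 3 to compound 4 (0.28 log units; within the scatter), also within the scatter, whereas against the 4-chloro-3-fluorophenyl group it is a 2.8-fold lower number from compound 1 to compound 4 (0.45 log units; beyond the scatter), so of the groups shown only that one stands clearly apart from the new group. No measurement here explains why these numbers differ.

From the compounds shown here alone, all four groups contain a six-membered aromatic ring of carbon only, so how a cyclohexyl group or a phenyl ring carrying an amine would behave in this assay remains open. Going by these compounds, whether the ring oxygen matters also remains open, and a matching five-membered ring of carbon only would test that.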